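From 3-Chlorophenyl to 4-Methoxyphenyl on a Shared Core

The compounds below may be only part of what the source reports. "The series", "measured", "known", "first", "only" and "open" are said of these compounds alone.

Of the compounds shown here, two with the same core have been tested in a functional assay on MCF7 cells (Homo sapiens) for antiproliferative activity, read by CCK-8 assay, with a stated time of 72 h; a higher number here means a weaker inhibitor, a lower number a stronger inhibitor. Compound 1 `Cc1cc(Nc2cc(N3CCN(C)CC3)nc(Nc3ccc(Cl)cc3)n2)n[nH]1` carries 4-chlorophenyl on a nitrogen on an aromatic ring and gives 840 nM. Compound 2 `Cc1cc(Nc2cc(N3CCN(C)CC3)nc(Nc3cccc(Cl)c3)n2)n[nH]1` carries 3-chlorophenyl in that place and gives 436 nM. These two numbers lie within the scatter of each other, so compound 2 holds no clear rank in this small set.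

Compound 3 `COc1ccc(Nc2nc(Nc3cc(C)[nH]n3)cc(N3CCN(C)CC3)n2)cc1` has not yet been measured. In it, 4-methoxyphenyl takes the place of 3-chlorophenyl on a nitrogen on an aromatic ring: 4-methoxyphenyl in place of 3-chlorophenyl on a nitrogen on an aromatic ring. Among the measured compounds shown here, no measured step swaps a chlorophenyl for a methoxyphenyl, so the data offer no direct precedent. For the measured compounds named here, the only guide is a change at this same place, a 1.9-fold lower number from compound 1 to compound 2 (0.28 log units; within the scatter). On that thin evidence, no step beyond the scatter is expected in this assay, although a surprise in either direction remains possible. The estimated step is a 1.4-fold higher number from compound 2 to compound 3 (0.14 log units; within the scatter). For compound 3, the estimated value is 600 nM, with an expected range from 200 nM to 1800 nM.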

Compound 3, half-maximal inhibitory concentration: 2750 nM
Compound 3: middle estimate off by 4.6-fold (0.66 log units), on the low side; the whole stated range lies below it.
By their numbers in this assay, from the lowest: compounds 2 and 1 (each within the scatter of the next); then compound 3.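

In this assay, the group on this nitrogen now proves able to move the number beyond the scatter: 4-methoxyphenyl in place of 3-chlorophenyl gives a 6.3-fold higher number from compound 2 to compound 3 (0.80 log units; beyond the scatter) in this three-compound set. The comparison with the other chlorinated compound points the same way, since methoxy in place of chloro on an aromatic carbon gives a 3.3-fold higher number from compound 1 to compound 3 (0.52 log units; beyond the scatter) and the rest of the molecule stays the same. Shifting from 4-chlorophenyl to 3-chlorophenyl had given only a 1.9-fold lower number from compound 1 to compound 2 (0.28 log units; within the scatter), so among these compounds the clear change appears only when methoxy replaces chloro, while the two chlorophenyl compounds remain within the scatter of each other.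

No measurement shown here explains why the methoxy compound gives the higher number. On these data alone, it also remains open whether 3-methoxyphenyl would stay close to the chlorophenyl compounds or follow compound 3, and how an aromatic ring carrying an amine, a carboxylic acid or a longer chain would read at this same place.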